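The source may hold more compounds than are shown below. What is called first, only, known or untested is meant among the compounds shown, and "the series" means these compounds.

Measured so far in an ADME assay (liver) for metabolic stability, with Liver microsome (Homo sapiens) as the target, read by LC-MS, using microsomes and NADPH, tested at 1 uM; on this read-out higher numbers stand for a longer-lived compound and lower numbers for a shorter-lived compound:

Compound 1 `CC(C)(C)c1cc(NC(=O)[C@@H]2CCCCN2CC2CC2)no1`: 0.15 h
Compound 2 `CC(C)(C)c1cc(NC(=O)[C@@H]2CCCCN2C2CCOCC2)no1`: 0.317 h
Compound 3 `CC(C)(C)c1cc(NC(=O)[C@@H]2CCCCN2CC2CCOCC2)no1`: 0.183 h

All three share one core and differ only in the group carried on the amine nitrogen in the ring. Compound 3 gives the second highest of the three numbers. Its two neighbours both sit within the scatter of it: a 1.2-fold higher number from compound 1 to compound 3 (0.09 log units; within the scatter) and a 1.7-fold lower number from compound 2 to compound 3 (0.24 log units; within the scatter), so no order among these three can be read with confidence.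

Compound 4 `CC(C)(C)c1cc(NC(=O)[C@@H]2CCCCN2C(=O)N2CCCCC2)no1` is the next compound. It differs from compound 3 by (piperidin-1-yl)carbonyl in place of (oxan-4-yl)methyl on an amine nitrogen in a ring. For the measured compounds named here, this change brings a carbonyl directly onto the ring nitrogen, something none of the measured compounds has, so no measured step matches it closely. Going by the values given here, the steps that bear on it are the earlier exchanges at the same nitrogen: a 2.1-fold higher number from compound 1 to compound 2 (0.32 log units; beyond the scatter), a modest shift beyond the scatter, and a 1.7-fold lower number from compound 2 to compound 3 (0.24 log units; within the scatter), a shift within it. Those swaps moved the number only slightly, so a step of similar or smaller size is expected here, in either direction, and most likely none beyond the scatter.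

The step from compound 3 to compound 4 is therefore estimated at a 1.6-fold higher number from compound 3 to compound 4 (0.21 log units; within the scatter). Compound 4 is expected to give 0.3 h, with a range from 0.1 h to 0.9 h.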

Compound 4, half-life: 0.233 h
Compound 4: the middle estimate sits 1.3-fold (0.11 log units) above what was measured, and the stated range covers the measured number.
By their numbers in this assay, from the lowest: compounds 1, 3, 4 and 2 (each within the scatter of the next, the first and the last beyond it).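

In this assay, the new group on an amine nitrogen in a ring, (piperidin-1-yl)carbonyl, joins that nitrogen through a carbonyl, a link absent from the three earlier compounds. The steps of a 1.3-fold higher number from compound 3 to compound 4 (0.10 log units; within the scatter) and a 1.4-fold lower number from compound 2 to compound 4 (0.13 log units; within the scatter) and also a 1.6-fold higher number from compound 1 to compound 4 (0.19 log units; within the scatter) show that this different link gives a half-life within the scatter of all three earlier compounds. At this position, then, a group joined through a carbonyl can take the place of one joined through a saturated carbon with no reliable shift in the number, and nothing measured here gives a reason for that.

What these compounds leave open is whether that holds for carbonyl groups of other shapes, such as a small acetyl or an open-chain dimethylaminocarbonyl, or for a link of another kind, such as a sulfonyl group. It is also unknown whether a group carrying a carboxylic acid or a free amine on this nitrogen would lift the half-life clearly beyond the narrow band that these four compounds occupy.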